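The compounds below may be only part of what the source reports. "The series", "measured", "known", "first", "only" and "open" are said of these compounds alone.

Measured so far:
compound 1 `COc1ccc(/C=C/C(=O)c2ccccc2F)c(OC)c1`: 87.3 nM
compound 2 `COc1cc(OC)c(OC)cc1/C=C/C(=O)c1ccccc1F`: 79 nM
compound 3 `COc1ccc(C(=O)/C=C/c2cc(OC)c(OC)c(OC)c2)c(F)c1`: 108 nM

All three were tested in a functional assay on A549 cells (Homo sapiens) for cytotoxicity, read by MTT assay, with a stated time of 72 h; on this read-out lower numbers stand for stronger inhibition and higher numbers for weaker inhibition. The three numbers lie within the usual scatter of one another, so no order among compounds 1, 2 and 3 can be read from them. Compound 1 arises from compound 2 by one change: hydrogen in place of methoxy on an aromatic carbon This made a 1.1-fold higher number from compound 2 to compound 1 (0.04 log units; within the scatter). Compound 4 `COc1cc(/C=C/C(=O)c2ccc(OC)cc2F)cc(OC)c1` is not yet measured. It arises from compound 3 by the same kind of change: hydrogen in place of methoxy on an aromatic carbon The surroundings are not the same, though: in compound 2 the leaving methoxy sits ortho to a methoxy group, meta to a large group and para to a methoxy group, whereas in compound 3 it sits ortho to two methoxy groups and para to a large group. How the core of compound 3 differs from that of compound 2 is not broken down here. Because the earlier step of a 1.1-fold higher number from compound 2 to compound 1 (0.04 log units; within the scatter) stayed within the scatter, the expected step of a 1.7-fold higher number from compound 3 to compound 4 (0.22 log units; within the scatter) is kept modest, with the different surroundings leaving room for a larger shift. Compound 4 is therefore estimated at 180 nM, between 70 nM and 500 nM.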

Compound 4, half-maximal inhibitory concentration: 101 nM
Beside the measured number, compound 4's estimate is 1.8-fold (0.25 log units) above it; measured number inside the range.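

Putting hydrogen in place of methoxy gives a 1.1-fold lower number from compound 3 to compound 4 (0.03 log units; within the scatter) in this assay. Set beside the earlier case of the same change, the two steps agree: the same change on two cores in this assay, a 1.1-fold higher number (0.04 log units; within the scatter) from compound 2 to compound 1 and a 1.1-fold lower number (0.03 log units; within the scatter) from compound 3 to compound 4, 1.2-fold (0.07 log units) apart, within the scatter of two such steps On these two cores, then, the change leaves no readable mark on the cytotoxicity number, even though the methoxy group leaves different surroundings in each; this does not show that the change is without effect on every core in the series, as two pairs are only two cases and a shift smaller than the usual scatter would stay hidden.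

The changed place holds only methoxy or hydrogen in the compounds shown, so it remains open how an amine, a carboxylic acid or a longer chain such as butoxy would behave there. Also open, going by these compounds, is whether the same agreement between steps would hold on a core without the fluorine atom, or in a different assay.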